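Stereochemical inversion of the hydroxypyrrolidine in a stilbene series

A few compounds are considered here, and "the series" means these few. Any claim that something is new, unique, unknown or untested is made for them only; others in the source may bear on it.

Measured compounds:
- compound 1, `COc1ccc(/C=C\c2cc(OC)c(OC)c(OC)c2)cc1OCc1ccc(CNCCO)cc1`: 1200 nM
- compound 2, `COc1ccc(/C=C\c2cc(OC)c(OC)c(OC)c2)cc1OCc1ccc(CN2CC[C@H](O)C2)cc1`: 7200 nM

In a functional assay on MC-38 cells (Mus musculus) for antiproliferative activity, read by CCK-8 assay, with a stated time of 48 h (on this read-out lower numbers stand for stronger inhibition and higher numbers for weaker inhibition), compound 1 gives 1200 nM. Going by the values given here, compound 2 gives 7200 nM in this assay and thus stands as the higher of the two numbers recorded so far; its nearest neighbour is compound 1, and the only measured step, a 6.0-fold higher number from compound 1 to compound 2 (0.78 log units; beyond the scatter), separates them. That step concerns the exchange of the amine substituent on the benzylic carbon and does not touch configuration.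

Compound 3, `COc1ccc(/C=C\c2cc(OC)c(OC)c(OC)c2)cc1OCc1ccc(CN2CC[C@@H](O)C2)cc1`, is the next member to be tested. Its relation to compound 2: the two compounds have the same atoms and bonds and differ only in configuration as drawn: 1 of 2 stereo elements differ; a stereocentre at a saturated ring carbon is drawn S in compound 2 and R in compound 3. Among the compounds with values here, no measured pair differs by configuration alone, so no recorded step bears directly on this change; the one step available, a 6.0-fold higher number from compound 1 to compound 2 (0.78 log units; beyond the scatter), informs only the nature of the amine substituent. The expected step from compound 2 to compound 3 in this assay is therefore set at a 1.2-fold lower number from compound 2 to compound 3 (0.08 log units; within the scatter), with a wide range to cover either direction. Compound 3 is estimated at 6000 nM in this assay, within 1500 nM to 25000 nM.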

Compound 3, half-maximal inhibitory concentration: 6900 nM
Beside the measured number, compound 3's estimate is 1.2-fold (0.06 log units) below it; the measured number falls inside the stated range.
By their numbers in this assay, from the lowest: compound 1; then compounds 3 and 2 (each within the scatter of the next).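

In this assay, the S and R forms of the 3-hydroxypyrrolidin-1-yl group are not separated, with a 1.0-fold lower number from compound 2 to compound 3 (0.02 log units; within the scatter). The gap to the (2-hydroxyethyl)amino group is therefore not confined to the S form, as it appears with the R form too: a 5.8-fold higher number from compound 1 to compound 3 (0.76 log units; beyond the scatter), alongside the earlier 6.0-fold higher number from compound 1 to compound 2 (0.78 log units; beyond the scatter). At this ring carbon, configuration alone is the variable tested, so the reading is a direct one for this position in this assay: the fact that compounds 2 and 3 differ only in the configuration as drawn.

The compounds shown leave open which feature of the 3-hydroxypyrrolidin-1-yl group goes with the higher numbers of compound 2 and compound 3 relative to compound 1: the closed ring, the attachment of the amine nitrogen or the placement of the hydroxyl. A pyrrolidine without the hydroxyl, a 4-hydroxypiperidine or a longer chain such as (3-hydroxypropyl)amino on the same saturated chain carbon would help separate these possibilities.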